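Amide to urea at the outer anilide of compound 1

A few compounds are considered here, and "the series" means these few. Any claim that something is new, unique, unknown or untested is made for them only; others in the source may bear on it.

Measured compounds:
compound 1 `O=C(Nc1ccc(-n2ccc3c(NC(=O)c4ccccc4)ncnc32)cc1)c1ccc(Cl)c(C(F)(F)F)c1`: 2300 nM
compound 2 `Nc1ncnc2c1ccn2-c1ccc(NC(=O)Nc2cc(C(F)(F)F)cc(C(F)(F)F)c2)cc1`: 3000 nM
compound 3 `CC(=O)Nc1ncnc2c1ccn2-c1ccc(NC(=O)c2ccc(Cl)c(C(F)(F)F)c2)cc1`: > 10000 nM

In a functional assay on A375P cells (Homo sapiens) for antiproliferative activity, read by MTT assay, with a stated time of 24 h (a lower number here means a stronger inhibitor, a higher number a weaker inhibitor), compound 1 gives 2300 nM. Compound 2 gives 3000 nM in this assay, and the two numbers lie within the usual scatter of each other, so neither can be set above the other. Compound 3 is reported only as a limit of this assay, > 10000 nM, not as a number. For the measured compounds named here, the one measured step that joins two compounds differing in a single place runs an at least 4.3-fold higher number from compound 1 to compound 3 (0.63 log units; beyond the scatter), at which compound 3 reaches (the limit of > 10000 nM in this assay, at which 1 of the 3 values shown sits); that step changes the acyl group on the core nitrogen and says nothing about the outer anilide.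

Compound 4 `O=C(Nc1ccc(-n2ccc3c(NC(=O)c4ccccc4)ncnc32)cc1)Nc1ccc(Cl)c(C(F)(F)F)c1` is the urea counterpart of compound 1: the change is (4-chloro-3-(trifluoromethyl)phenyl)amino in place of 4-chloro-3-(trifluoromethyl)phenyl on a carbonyl carbon. Going by the values given here, no measured pair isolates this change. Compound 2 carries a urea at the outer anilide but also differs from compound 1 at the core, so its value cannot be read as a step. With nothing to point one way or the other, the step is expected to stay within the scatter: compound 4 is estimated at 2000 nM, between 700 nM and 6000 nM, a step of a 1.2-fold lower number from compound 1 to compound 4 (0.06 log units; within the scatter).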

Compound 4, half-maximal inhibitory concentration: 4600 nM
For compound 4 the middle estimate is 2.3-fold (0.36 log units) below the measured one, within the range that was stated.
By their numbers in this assay, from the lowest: compounds 1, 2 and 4 (each within the scatter of the next). At a limit, above all of these: compound 3.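

For the compounds shown here, the pair gives the first direct reading at the outer anilide, since the only earlier step concerned the acyl group on the core nitrogen. In this assay, putting (4-chloro-3-(trifluoromethyl)phenyl)amino in place of 4-chloro-3-(trifluoromethyl)phenyl on this carbonyl carbon gives a 2.0-fold higher number from compound 1 to compound 4 (0.30 log units; within the scatter), so amide and urea cannot be told apart here when the rest of compound 1 is kept. Nothing measured here explains why this change leaves the reading within the scatter.

From the compounds shown here alone, what remains open is whether the same holds with a different link at this carbonyl carbon, such as a methylene group or an ether oxygen in place of the amino group, and whether it holds on a core that carries a free amine instead of the benzoyl amide of compound 1. Also open, going by these compounds, is how the outer ring itself contributes, for example with a nitrile or a methoxy group in place of the chlorine, since the amide and urea of this pair share the same 4-chloro-3-(trifluoromethyl)phenyl ring.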